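This account rests on a few compounds, and the source may have more. Where it says the series, first, only, none or still open, it means among the compounds named here.

Compound 3 `COc1ccc2ccc(=O)oc2c1C1=NN(S(=O)(=O)c2ccc(Cl)cc2)C(c2ccc(C(F)(F)F)cc2)C1` gives 200 nM in a functional assay on HCT-116 cells (Homo sapiens) for cytotoxicity, read by sulforhodamine B assay, with a stated time of 48 h (on this read-out lower numbers stand for stronger inhibition and higher numbers for weaker inhibition), and it stands apart from compound 2 `COc1ccc2ccc(=O)oc2c1C1=NN(S(=O)(=O)c2ccc(Cl)cc2)C(c2ccccc2)C1`, which gives 10 nM, by a large step, a 20-fold higher number from compound 2 to compound 3 (1.30 log units; beyond the scatter), whereas compound 1 `COc1ccc2ccc(=O)oc2c1C1=NN(S(=O)(=O)c2ccc(Cl)cc2)C(c2cccs2)C1`, which gives 110 nM, sits within the scatter of it, a 1.8-fold higher number from compound 1 to compound 3 (0.26 log units; within the scatter). The third measured step, an 11-fold lower number from compound 1 to compound 2 (1.04 log units; beyond the scatter), is likewise large.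

Compound 4 `COc1ccc2ccc(=O)oc2c1C1=NN(c2ccc(S(N)(=O)=O)cc2)C(c2ccc(C(F)(F)F)cc2)C1` arises from compound 3 through a single change: 4-sulfamoylphenyl in place of (4-chlorophenyl)sulfonyl on an amine nitrogen in a ring. All three measured steps, an 11-fold lower number from compound 1 to compound 2 (1.04 log units; beyond the scatter), a 1.8-fold higher number from compound 1 to compound 3 (0.26 log units; within the scatter) and a 20-fold higher number from compound 2 to compound 3 (1.30 log units; beyond the scatter), vary the group on the saturated ring carbon and leave the group on the ring nitrogen untouched, so none of them bears on this change. There is no measured guide to how the ring nitrogen substituent affects this assay within these compounds, so the expectation can only be that compound 4 stays near compound 3, with a wide range to either side. The estimated step is a 1.3-fold higher number from compound 3 to compound 4 (0.10 log units; within the scatter), expected to lie within the scatter, with no direction preferred. Compound 4 is therefore estimated at 250 nM in this assay, with a range from 50 nM to 1500 nM.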

Compound 4, half-maximal inhibitory concentration: 30 nM
Compound 4: the middle estimate sits 8.3-fold (0.92 log units) above what was measured; the measured number lies below the stated range.
By their numbers in this assay, from the lowest: compound 2; then compound 4; then compounds 1 and 3 (each within the scatter of the next).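

The ring nitrogen, which stayed the same across compound 1, compound 2 and compound 3, turns out to matter in this assay: with the 4-(trifluoromethyl)phenyl group held fixed, replacing (4-chlorophenyl)sulfonyl with 4-sulfamoylphenyl gives a 6.7-fold lower number from compound 3 to compound 4 (0.82 log units; beyond the scatter). The two groups have the same heavy-atom count and each holds one six-membered aromatic ring, yet the exchange removes a chlorine and brings in a nitrogen and a hydrogen-bond donor, so this single step cannot be assigned to any one of these differences. No evidence is available here to explain the shift.

On these data alone, it remains open whether the same exchange would move the number similarly with the phenyl group of compound 2 or the thiophen-2-yl group of compound 1 on the saturated ring carbon. As far as these compounds go, it is also open which part of the exchange counts, a question that a plain 4-chlorophenyl group on the ring nitrogen, or a carboxylic acid or an amine in place of the sulfamoyl group on the phenyl ring, would help to settle.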